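Furan for Thiophene on Two Nucleoside Cores

The compounds below may be only part of what the source reports. "The series", "measured", "known", "first", "only" and "open" are said of these compounds alone.

Compound 3 `Cc1ncnc2c1c(-c1cccs1)cn2[C@@H]1O[C@H](CO)[C@@H](O)[C@H]1O` and compound 1 `Cc1ncnc2c1c(-c1ccoc1)cn2[C@@H]1O[C@H](CO)[C@@H](O)[C@H]1O` share one core and differ in a single place, where compound 1 carries furan-3-yl in place of thiophen-2-yl (furan-3-yl in place of thiophen-2-yl on an aromatic carbon). In a functional assay on CCRF-CEM cells (Homo sapiens), read by MTT assay, with a stated time of 72 h (on this read-out higher numbers stand for weaker inhibition and lower numbers for stronger inhibition), compound 3 reaches only a limit, > 20000 nM. Compound 1 reaches only a limit as well in this assay, > 20000 nM. The step that the two limits leave unreadable from compound 3 to compound 1 cannot be sized, because of the limit of > 20000 nM in this assay, at which 3 of the 3 values shown sit. Compound 2 `Nc1nc2c(c(-c3cccs3)cn2[C@@H]2O[C@H](CO)[C@@H](O)[C@H]2O)c(=O)[nH]1` stands on a second core; the difference between the two cores is not broken down here. In this assay compound 2 gives only a limit, > 20000 nM. Compound 4 `Nc1nc2c(c(-c3ccoc3)cn2[C@@H]2O[C@H](CO)[C@@H](O)[C@H]2O)c(=O)[nH]1`, not yet measured, arises from compound 2 by the same change (furan-3-yl in place of thiophen-2-yl on an aromatic carbon). The step that the limit leaves unreadable from compound 2 to compound 4 is expected to stay unreadable, resting on compound 3 and compound 1 both sitting at the limit of > 20000 nM in this assay, at which 3 of the 3 values shown sit. Compound 4 is therefore estimated at 30000 nM, within 15000 nM to 80000 nM.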

Compound 4, half-maximal inhibitory concentration: 17900 nM
Compound 4: middle estimate off by 1.7-fold (0.22 log units), on the high side; the range from low to high includes it.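

On the second core, furan-3-yl in place of thiophen-2-yl gives in this assay an at least 1.1-fold lower number from compound 2 to compound 4 (0.04 log units; that floor lies within the scatter). This floor shows neither that the change strengthens inhibition nor that it leaves inhibition unchanged, since the true size of the step could be larger. The step on the first core cannot be read, so the data do not show whether the change acts alike on the two cores, because nearly all the values here are limits: the limit of > 20000 nM in this assay, at which 3 of the 4 values shown sit.

The compounds shown leave open whether any group at this place gives a reading clear of that limit in this assay. A phenyl ring or an amine, for example, stands outside the part of the series shown here.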